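Replacing 3,5-dimethoxyphenyl with 3-hydroxyphenyl: working notes

A few compounds are considered here, and "the series" means these few. Any claim that something is new, unique, unknown or untested is made for them only; others in the source may bear on it.

Measured in a functional assay on A549 cells (Homo sapiens) for cytotoxicity, read by MTT assay, with a stated time of 72 h; a higher number here means a weaker inhibitor, a lower number a stronger inhibitor:
- Compound 1 `COc1cc(Nc2nc3ccccc3nc2S(=O)(=O)c2ccc(C)cc2)cc(OC)c1` gives 8060 nM
- Compound 2 `COc1ccc(Nc2nc3ccccc3nc2S(=O)(=O)c2ccc(Br)cc2)cc1` gives 3340 nM
- Compound 3 `COc1cc(Nc2nc3ccccc3nc2S(=O)(=O)c2ccc(Br)cc2)cc(OC)c1` gives 15900 nM

Compound 3 lies in the upper part of these three numbers. The exchange of methyl for bromo shows a 2.0-fold higher number from compound 1 to compound 3 (0.30 log units; within the scatter), so those two values are not told apart. The exchange on the nitrogen shows a 4.8-fold higher number from compound 2 to compound 3 (0.68 log units; beyond the scatter), which separates these two values clearly.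

The next compound is compound 4 `O=S(=O)(c1ccc(Br)cc1)c1nc2ccccc2nc1Nc1cccc(O)c1`, with 3-hydroxyphenyl in place of 3,5-dimethoxyphenyl on a nitrogen on an aromatic ring. The bromo and methyl step lies elsewhere in the structure and says little about this change. Going by the values given here, the only measured step at this place is a 4.8-fold higher number from compound 2 to compound 3 (0.68 log units; beyond the scatter), where the 4-methoxyphenyl group of compound 2 gives the lower number. Among the compounds with values here, no measured compound carries 3-hydroxyphenyl, so this is a single, indirect guide. Leaving 3,5-dimethoxyphenyl is therefore expected to lower the number in this assay, by somewhat less than that measured step, and the expected change is a 2.4-fold lower number from compound 3 to compound 4 (0.39 log units; beyond the scatter). For compound 4 the estimated value is 6500 nM, with an expected range of 2500 nM to 17000 nM.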

Compound 4, half-maximal inhibitory concentration: 8000 nM
For compound 4 the middle estimate is 1.2-fold (0.09 log units) below the measured one; low and high end bracket the measured number.
By their numbers in this assay, from the lowest: compound 2; then compounds 4, 1 and 3 (each within the scatter of the next).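

Within this assay, exchanging 3,5-dimethoxyphenyl for 3-hydroxyphenyl on the nitrogen gives a step within the scatter (a 2.0-fold lower number from compound 3 to compound 4 (0.30 log units; within the scatter)), so these two groups are not told apart, although they differ in heavy atoms and 3-hydroxyphenyl carries 1 hydrogen-bond donor where 3,5-dimethoxyphenyl carries 0. The exchange of 4-methoxyphenyl for 3-hydroxyphenyl gives a modest step beyond the scatter (a 2.4-fold higher number from compound 2 to compound 4 (0.38 log units; beyond the scatter)), so 4-methoxyphenyl now stands apart from both other groups at this place, with the lower number in each comparison. No available evidence bears on the reason for this ordering at the nitrogen.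

The compounds shown do not settle whether the lower number of compound 2 is tied to 4-methoxyphenyl itself, and 3-methoxyphenyl, 4-hydroxyphenyl or 3-aminophenyl on the same nitrogen would test that reading directly. From the compounds shown here alone, it also stays open whether the same ordering holds with methyl in place of bromo, since 3-hydroxyphenyl and 4-methoxyphenyl appear here only with bromo.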